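A few compounds are considered here, and "the series" means these few. Any claim that something is new, unique, unknown or untested is made for them only; others in the source may bear on it.

Working notes on the series. Compound 1 `ClCc1ccc(Cn2cnc3c(Cl)ncnc32)cc1` gives 26900 nM in a functional assay on A498 cells (Homo sapiens) for cytotoxicity, read by sulforhodamine B assay, with a stated time of 48 h (on this read-out lower numbers stand for stronger inhibition of growth and higher numbers for weaker inhibition of growth), the highest of the two numbers recorded. Compound 2 `ClCc1ccccc1Cn1cnc2c(Cl)nc(Cl)nc21` gives 4780 nM in this assay, a lower number by a margin beyond the scatter; compound 2 and compound 1 differ in more than one place, so their two values are noted side by side without a step being drawn from them. Compound 3 `Nc1nc(Cl)c2ncn(Cc3ccc(CCl)cc3)c2n1` has not been measured in this assay. It differs from compound 1 by amino in place of hydrogen on an aromatic carbon. Within the data shown here, no step between measured compounds covers this change, so the expected effect rests on nothing more than the shared core of compound 1 and the amino group entering. A step within the scatter, or only modestly beyond it toward a lower number, is expected, written as a 1.8-fold lower number from compound 1 to compound 3 (0.25 log units; within the scatter). Compound 3 is accordingly expected to give 15000 nM in this assay, within a range from 4000 nM to 50000 nM.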

Compound 3, concentration for total growth inhibition: 85100 nM
Compound 3: the middle estimate sits 5.7-fold (0.75 log units) below what was measured; the whole stated range lies below it.
By their numbers in this assay, from the lowest: compound 2; then compound 1; then compound 3.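

Amino in place of hydrogen is the first single change that can be read in this series, and in this assay it moves toward weaker inhibition of growth, with a 3.2-fold higher number from compound 1 to compound 3 (0.50 log units; beyond the scatter) at the aromatic carbon between two ring nitrogen atoms. The step is modest but beyond the scatter, so on this read-out the position does not tolerate the change silently, at least on the core of compound 1. Nothing at hand bears on why the number moves in this direction.

Amino is the only group shown entering at this carbon, so it remains open whether a methylamino, a dimethylamino or a methoxy group there would move the number the same way or further. Also open, going by these compounds, is whether the step would hold with a methoxy group in place of the chloro group on the same ring.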